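One Heteroaryl Sulfide Replaces Another on the Shared Core

The source may hold more compounds than are shown below. What is called first, only, known or untested is meant among the compounds shown, and "the series" means these compounds.

Among the compounds with values here, compound 2 `Cn1c(-c2ccc(NC(=O)CSc3nc4cc(Cl)ccc4o3)cc2)nc(-c2ccccc2)c1-c1ccccc1` gives 40% in a functional assay on MCF7 cells (Homo sapiens) for cytotoxicity, read by MTT assay, with a stated time of 24 h, tested at 16 ug/mL (on this read-out higher numbers stand for a stronger effect at the one concentration tested and lower numbers for a weaker effect), the higher of the two numbers measured so far. Its nearest neighbour is compound 1 `Cn1c(-c2ccc(NC(=O)CCl)cc2)nc(-c2ccccc2)c1-c1ccccc1`, which in this assay gives 15.2%. Within the data shown here, the single measured step, a number 24.8 percentage points higher from compound 1 to compound 2 (beyond the scatter), concerns a different change, namely the replacement of a chloro on a saturated chain carbon bound to a carbonyl carbon by a whole heteroaryl sulfanyl group, so it bears only loosely on what follows. Compound 3 `Cn1c(-c2ccc(NC(=O)CSc3nc4ccccc4s3)cc2)nc(-c2ccccc2)c1-c1ccccc1` differs from compound 2 in one place: 1,3-benzothiazol-2-yl in place of 5-chloro-1,3-benzoxazol-2-yl on a sulfur. Among the measured compounds shown here, no measured step tests the exchange of one such aryl group on the sulfur for another. Compound 3 is therefore expected to stay close to compound 2, with a number 2 percentage points lower from compound 2 to compound 3 (within the scatter) not going beyond the scatter in either direction. Compound 3 is estimated at 38%, within 20% to 56%.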

Compound 3, a percentage reported as activity, at one concentration (the size of the read-out at that concentration, not a potency): 50.3%
The estimate for compound 3 lay 12.3 percentage points below the measured number; the range from low to high includes it.
By their numbers in this assay, from the lowest: compound 1; then compound 2; then compound 3.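

In this assay, the aryl group on the sulfur proves to matter: 1,3-benzothiazol-2-yl in place of 5-chloro-1,3-benzoxazol-2-yl gives a number 10.3 percentage points higher from compound 2 to compound 3 (beyond the scatter), so the number responds to which heteroaryl group is carried, not only to the loss of the chloro. Set against the chloro on the saturated chain carbon, the (1,3-benzothiazol-2-yl)sulfanyl group gives a number 35.1 percentage points higher from compound 1 to compound 3 (beyond the scatter), the largest step among these compounds. The exchange on the sulfur removes the chlorine and puts a ring sulfur where the ring oxygen stood, and no measurement offers an explanation for the step or separates these two changes.

The compounds shown leave open how the unsubstituted 1,3-benzoxazol-2-yl or 5-chloro-1,3-benzothiazol-2-yl group would stand. They also leave open whether a sulfanyl link is needed at all, or whether an amine such as morpholine could take its place on the chain carbon.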